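The source may report more compounds than this note shows. Statements on the series, on what has been measured and on what is new or still open speak of the compounds shown alone.

Measured so far in an ADME assay on A549 cells (Homo sapiens) for cytotoxicity, read by resazurin assay, with a stated time of 48 h; on this read-out lower numbers stand for higher toxicity in this test and higher numbers for lower toxicity in this test:

- Compound 1 `CCCCCCC(C)Nc1ccc(NC(=O)c2cc(Cl)ccc2O)c(Cl)c1`: 23500 nM
- Compound 2 `O=C(Nc1ccc(NCc2cccnc2Cl)cc1Cl)c1cc(Cl)ccc1O`: 101000 nM
- Compound 3 `O=C(Nc1ccc(NCc2ccc3cn[nH]c3c2)cc1Cl)c1cc(Cl)ccc1O`: 45300 nM

On these numbers, compound 3 sits in the middle ground. Its value of 45300 nM lies within the usual scatter of that of compound 1, so the two cannot be told apart. Compound 2 stands clearly apart from it, as a 2.2-fold lower number from compound 2 to compound 3 (0.35 log units; beyond the scatter) shows.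

The next compound to be tested is compound 4 `O=C(Nc1ccc(NCCCO)cc1Cl)c1cc(Cl)ccc1O`. It carries 2-hydroxyethyl in place of 1H-indazol-6-yl on a saturated chain carbon bound to a nitrogen on an aromatic ring.

Two measured steps changed the group in this same region: a 4.3-fold higher number from compound 1 to compound 2 (0.63 log units; beyond the scatter) and a 2.2-fold lower number from compound 2 to compound 3 (0.35 log units; beyond the scatter). Both are modest, and they run in opposite directions. Among the compounds with values here, neither gives a direct guide, since no measured compound carries 2-hydroxyethyl here. With only modest steps to go on, a large change in this assay seems unlikely. The estimated change is a 1.5-fold higher number from compound 3 to compound 4 (0.19 log units; within the scatter), which is not expected to go beyond the scatter. For compound 4 the expected value is 70000 nM, with an estimated range from 30000 nM to 160000 nM.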

Compound 4, half-maximal cytotoxic concentration: 106000 nM
Compound 4: middle estimate off by 1.5-fold (0.18 log units), on the low side; low and high end bracket the measured number.
By their numbers in this assay, from the lowest: compounds 1 and 3 (each within the scatter of the next); then compounds 2 and 4 (each within the scatter of the next).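

In this assay, 2-hydroxyethyl, an open chain with no ring, gives a 2.3-fold higher number from compound 3 to compound 4 (0.37 log units; beyond the scatter) when it replaces 1H-indazol-6-yl, so a fused ring pair is not needed at this place for a high number. Against 2-chloropyridin-3-yl the same chain gives a 1.0-fold higher number from compound 2 to compound 4 (0.02 log units; within the scatter) and the two compounds cannot be told apart, which shows that a ring as such does not fix the number here, since one ring-bearing group and the ring-free chain end up level while the other ring-bearing group stays lower. Within the data shown here, the step of a 4.5-fold higher number from compound 1 to compound 4 (0.65 log units; beyond the scatter) on replacing 1-methylheptyl with 3-hydroxypropyl adds the first comparison of two open chains on this nitrogen, and it shows that an open chain alone does not settle the outcome either.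

Going by these compounds, what remains open is whether the hydroxyl or the chain length matters more, which a plain propyl chain, a longer chain ending in hydroxyl, or a chain ending in an amine or a carboxylic acid could help to separate. No accompanying measurement explains any of these steps.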